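Five-membered thioamide series, substituent on the ring nitrogen

A few compounds are considered here, and "the series" means these few. Any claim that something is new, unique, unknown or untested is made for them only; others in the source may bear on it.

Measured compounds:
compound 1, `Cc1cc(C)n(-c2ccc(S(=O)(=O)N3CC(=O)N(Cc4ccccc4)C3=S)cc2)n1`, 1%
compound 2, `Cc1cc(C)n(-c2ccc(S(=O)(=O)N3CC(=O)N(C4CCCCC4)C3=S)cc2)n1`, 2%
compound 3, `C=CCN1C(=O)CN(S(=O)(=O)c2ccc(-n3nc(C)cc3C)cc2)C1=S`, 4%

All three share one core and differ only in the group on the amide-type nitrogen in the ring. In a functional assay on the whole organism (blood, strain albino) with Mus musculus as the target, with stated times of 6 days and 4 h, at a dose of 1 mmol/kg by the oral route (a lower number here means less inhibition, a higher number more inhibition at the dose given (going by the name of the read-out)), compound 3 gives 4%. Its number is the largest of the three, but a number 3 percentage points higher from compound 1 to compound 3 (within the scatter) and a number 2 percentage points higher from compound 2 to compound 3 (within the scatter) both lie within the scatter, so compound 3 does not separate from compound 1 or compound 2. The remaining step, a number 1 percentage points higher from compound 1 to compound 2 (within the scatter), is likewise within the scatter. Every exchange tried so far at this nitrogen, whether benzyl, cyclohexyl or allyl, has left the read-out essentially unchanged.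

Compound 4, `Cc1cc(C)n(-c2ccc(S(=O)(=O)N3CC(=O)N(c4ccccc4)C3=S)cc2)n1`, has not yet been measured. It differs from compound 3 by phenyl in place of allyl on an amide-type nitrogen in a ring. Going by these compounds, the three measured steps all concern this same position and were all within the scatter, so a step beyond the scatter is not expected here either; a phenyl directly on the ring nitrogen is untested, which is the only caution.

Compound 4 is expected to give 3%, with a range from 0% to 12%. The step of a number 1 percentage points lower from compound 3 to compound 4 (within the scatter) is thus expected to remain within the scatter.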

Compound 4, a percentage reported as inhibition, in the whole organism at one dose (the size of the read-out at that dose, not a potency): 8%
Compound 4: the middle estimate sits 5 percentage points below what was measured; low and high end bracket the measured number.
By their numbers in this assay, from the lowest: compounds 1, 2, 3 and 4 (each within the scatter of the next).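

In this assay phenyl on the amide-type nitrogen in a ring does not separate from any of the three earlier groups, since a number 4 percentage points higher from compound 3 to compound 4 (within the scatter) and a number 6 percentage points higher from compound 2 to compound 4 (within the scatter) and a number 7 percentage points higher from compound 1 to compound 4 (within the scatter) all hold for this one exchange. The earlier compounds shown here carried allyl, cyclohexyl or benzyl at this nitrogen, and none had a six-membered aromatic ring of carbon only bound to it directly. For the compounds shown here, this position now holds four groups of differing size and shape, with and without a ring, and no step among them leaves the scatter.

Going by these compounds, all four groups contain carbon only, so it remains open whether an amine, a carboxylic acid or a longer chain ending in a hydroxyl at this nitrogen would give a step beyond the scatter. Exchanges elsewhere on the shared core also remain open. Nothing at hand explains the numbers seen at this position.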